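Trading Dimethoxyphenyl for Phenyl in a Cytotoxicity Screen

A few compounds are considered here, and "the series" means these few. Any claim that something is new, unique, unknown or untested is made for them only; others in the source may bear on it.

Compound 1 `O=c1cc(Nc2ccccc2)sc2c([N+](=O)[O-])cc(C(F)(F)F)cc12`: > 64 ug/mL
Compound 2 `COc1ccc(CN(C)c2cc(=O)c3cc(C(F)(F)F)cc([N+](=O)[O-])c3s2)cc1OC`: > 64 ug/mL

In an ADME assay on Vero cells (Chlorocebus sabaeus) for cytotoxicity, read by MTT assay, with a stated time of 48 h (a lower number here means a stronger inhibitor, a higher number a weaker inhibitor), compound 1 gives > 64 ug/mL, which is a limit of the assay and not a number. Compound 2 likewise gives > 64 ug/mL, again a limit. Compound 2 thus stands at the limit of > 64 ug/mL in this assay, at which 2 of the 2 values shown sit. Within the data shown here, no step between two measured compounds is available here. Compound 3 `CN(Cc1ccccc1)c1cc(=O)c2cc(C(F)(F)F)cc([N+](=O)[O-])c2s1` differs from compound 2 by phenyl in place of 3,4-dimethoxyphenyl on a saturated chain carbon bound to a nitrogen on an aromatic ring. Because compound 2 rests at the limit of > 64 ug/mL in this assay, at which 2 of the 2 values shown sit, no step beyond the scatter is expected, a step that the limit leaves unreadable from compound 2 to compound 3. Compound 3 is therefore estimated at 100 ug/mL, between 50 ug/mL and 200 ug/mL.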

Compound 3, half-maximal inhibitory concentration: > 64 ug/mL
Compound 3: a limit, no number (the forecaster's own chance of this, stated with the estimate: 85%); the middle value lies beyond the limit too.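

No step can be read among compound 1, compound 2 and compound 3, since all three give only a limit and no number: the limit of > 64 ug/mL in this assay, at which 3 of the 3 values shown sit.

In this assay, from the compounds shown here alone, it stays open how far each compound lies past that limit, and whether they differ at all.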